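From Thiophen-2-ylmethyl to 4-Methoxyphenyl on the Shared Core

A few compounds are considered here, and "the series" means these few. Any claim that something is new, unique, unknown or untested is made for them only; others in the source may bear on it.

Measured in an assay on HL-60 cells for agonist activity at N-formyl peptide receptor 3 (Homo sapiens), read by calcium flux; a lower number here means that less compound is needed, a higher number that more compound is needed for the effect:
Compound 1 `Cc1cc(Cc2cccc(Br)c2)c(=O)n(CC(=O)Nc2ccc(Br)cc2)n1` gives > 50000 nM, a limit.
Compound 2 `Cc1cc(Cc2ccoc2)c(=O)n(CC(=O)Nc2ccc(Br)cc2)n1` gives > 50000 nM, also a limit.
Compound 3 `Cc1cc(Cc2cccs2)c(=O)n(CC(=O)Nc2ccc(Br)cc2)n1` gives 10200 nM.

Compound 3 thus holds the only number shown; the other two values sit at the limit of > 50000 nM in this assay, at which 2 of the 3 values shown sit. The change to compound 4 `COc1ccc(-c2cc(C)nn(CC(=O)Nc3ccc(Br)cc3)c2=O)cc1` is 4-methoxyphenyl in place of (thiophen-2-yl)methyl on an aromatic carbon. Among the compounds with values here, no measured step matches this swap. Within the data shown here, the nearest are an at least 4.9-fold lower number from compound 1 to compound 3 (0.69 log units; beyond the scatter) and an at least 4.9-fold lower number from compound 2 to compound 3 (0.69 log units; beyond the scatter), which show the thiophen-2-yl arm giving a lower number than two other arms; removing that arm altogether, and placing a new group directly on the ring carbon, has no precedent in this assay. Compound 4 is therefore expected near 20000 nM, between 5000 nM and 80000 nM, with a fair chance of only a limit. That estimate would mean a 2.0-fold higher number from compound 3 to compound 4 (0.29 log units; within the scatter).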

Compound 4, half-maximal effective concentration: > 50000 nM
Compound 4: a limit, no number; the forecaster's own chance of this, stated with the estimate: 40%; middle value at least 2.5-fold (0.39 log units) from the limit.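

The change from the (thiophen-2-yl)methyl group to 4-methoxyphenyl, set directly on the aromatic carbon, gives an at least 4.9-fold higher number from compound 3 to compound 4 (0.69 log units; beyond the scatter) in this assay, so the only arm with a readable number does not survive this swap. Compound 4 reads only as a limit: the limit of > 50000 nM in this assay, at which 3 of the 4 values shown sit.

The steps to compound 4 from compound 1 and from compound 2 join two limits and cannot be read. On these data alone, the swap removes the linking chain carbon and changes the ring at once, so which change matters stays open. A 4-methoxybenzyl group or a directly attached thiophen-2-yl would separate the two.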